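A few compounds are considered here, and "the series" means these few. Any claim that something is new, unique, unknown or untested is made for them only; others in the source may bear on it.

Of the compounds shown here, three sharing one core have been measured in an assay on isolated protein for inhibition of MAP kinase-interacting serine/threonine-protein kinase 2 (Homo sapiens), read by HTRF, in the presence of a further agent that is not named here; a lower number here means a stronger inhibitor, a higher number a weaker inhibitor. Compound 1 `COC(=O)c1oc2ccc(Nc3ncnc4ccc(Cl)nc34)cc2c1C` carries a methoxy group on the carbonyl carbon and gives 4800 nM. Compound 2 `Cc1c(C(=O)N(C)C)oc2ccc(Nc3ncnc4ccc(Cl)nc34)cc12` replaces this with dimethylamino and gives 2200 nM. Compound 3 `Cc1c(C(=O)N2CCNCC2)oc2ccc(Nc3ncnc4ccc(Cl)nc34)cc12` carries piperazin-1-yl at the same carbonyl carbon and gives 1900 nM. Compound 3 thus has the lowest of the three numbers, although the step of a 1.2-fold lower number from compound 2 to compound 3 (0.06 log units; within the scatter) lies within the scatter, so it cannot be set apart from compound 2; only against compound 1 is the step of a 2.5-fold lower number from compound 1 to compound 3 (0.40 log units; beyond the scatter) clear, as is a 2.2-fold lower number from compound 1 to compound 2 (0.34 log units; beyond the scatter).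

Compound 4 `CNC(=O)c1oc2ccc(Nc3ncnc4ccc(Cl)nc34)cc2c1C` makes a further change at this carbonyl carbon: methylamino in place of piperazin-1-yl on a carbonyl carbon. The step that bears on it most is the exchange of one amide substituent for another, a 1.2-fold lower number from compound 2 to compound 3 (0.06 log units; within the scatter), which was within the scatter. On that basis compound 4 is expected to show a step of a 1.4-fold higher number from compound 3 to compound 4 (0.14 log units; within the scatter), at most a modest weakening, and its value in this assay is estimated at 2600 nM, in a range from 1200 nM to 5500 nM.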

Compound 4, half-maximal inhibitory concentration: 2500 nM
The estimate for compound 4 lay 1.0-fold (0.02 log units) above the measured number, within the range that was stated.
By their numbers in this assay, from the lowest: compounds 3, 2, 4 and 1 (each within the scatter of the next, the first and the last beyond it).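

In this assay, the step from the ring of piperazin-1-yl to the open methylamino group, a 1.3-fold higher number from compound 3 to compound 4 (0.12 log units; within the scatter), lies within the scatter, so at this carbonyl carbon the ring is not required for a number in this range. Hydrogen in place of methyl on the amide-type nitrogen, a 1.1-fold higher number from compound 2 to compound 4 (0.06 log units; within the scatter), also lies within the scatter, so the amide hydrogen makes no readable difference here. The comparison with the methoxy group of the ester, a 1.9-fold lower number from compound 1 to compound 4 (0.28 log units; within the scatter), lies within the scatter too, so unlike compound 2 and compound 3, compound 4 cannot be set apart from compound 1. On these data alone, whether a carboxylic acid or an amide with a longer amine chain at this carbonyl carbon would give a step beyond the scatter stays open. Nothing measured here explains these results.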